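The source may report more compounds than this note shows. Statements on the series, on what has been measured and on what is new or still open speak of the compounds shown alone.

Measured compounds:
- Compound 1 `Cc1cc(=O)oc2cc(OCC(O)CN3CCC(C(N)=O)CC3)ccc12`: in an ADME assay on A549 cells (Homo sapiens) for cytotoxicity, read by CellTiter-Glo (on this read-out lower numbers stand for higher toxicity in this test and higher numbers for lower toxicity in this test), compound 1 stops at > 100000 nM, a limit of the assay.
- Compound 2 `Cc1c(Cc2ccc(F)cc2F)c(=O)oc2cc(OCC(O)CN3CCC(C(N)=O)CC3)ccc12`: in this assay compound 2 likewise stops at > 100000 nM, a limit of the assay.
- Compound 3 `Cc1c(Cc2ccc(OC(F)(F)F)cc2)c(=O)oc2cc(OCC(O)CN3CCC(C(N)=O)CC3)ccc12`: in this assay compound 3 gives 68200 nM.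

Within the data shown here, compound 3 is thus the only member of the three with a read number; the other two sit at the limit of > 100000 nM in this assay, at which 2 of the 3 values shown sit. The steps toward it are an at least 1.4-fold lower number from compound 1 to compound 3 (0.16 log units; that floor lies within the scatter) and an at least 1.4-fold lower number from compound 2 to compound 3 (0.16 log units; that floor lies within the scatter), each a floor only; the step that the two limits leave unreadable from compound 1 to compound 2 stays unreadable.

Compound 4 `Cc1c(Cc2ccc(-c3ccc(C=O)c(F)c3)cc2)c(=O)oc2cc(OCC(O)CN3CCC(C(N)=O)CC3)ccc12` has not been measured. It differs from compound 3 by 3-fluoro-4-formylphenyl in place of trifluoromethoxy on an aromatic carbon. Among the measured compounds shown here, of the measured steps, only the one from compound 2 to compound 3 also exchanges the group on that outer aromatic ring, and its floor lies within the scatter, so the data give no readable direction for a change at this position. Compound 4 is therefore expected to stay near compound 3, with a 1.2-fold lower number from compound 3 to compound 4 (0.09 log units; within the scatter) as the expected step, and the chance remains that the assay again reports only a limit. For compound 4 the estimate in this assay is 55000 nM, ranging from 20000 nM to 150000 nM.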

Compound 4, half-maximal cytotoxic concentration: 62400 nM
Estimate against measurement, compound 4: 1.1-fold (0.05 log units) below; measured number inside the range.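

In this assay, putting 3-fluoro-4-formylphenyl in place of trifluoromethoxy on this aromatic carbon gives a 1.1-fold lower number from compound 3 to compound 4 (0.04 log units; within the scatter). Among these compounds, this is the first change on the outer aromatic ring in which both compounds carry a read number, whereas the earlier steps gave only floors within the scatter. The entering group has 9 heavy atoms against 5 for the group that leaves and adds a six-membered aromatic ring of carbon only, yet within this single pair, that exchange produces no readable separation in this test.

The compounds shown leave open whether a plain phenyl, an amine or a carboxylic acid at this place would give a step beyond the scatter, and they do not separate the formyl group from the fluorine within the entering group. Compound 1 and compound 2 remain at a limit of the assay rather than a number, and the step between them cannot be read: the limit of > 100000 nM in this assay, at which 2 of the 4 values shown sit.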